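Swapping the outer phenyl substituents: an expected solubility change

The source may report more compounds than this note shows. Statements on the series, on what has been measured and on what is new or still open speak of the compounds shown alone.

Among the compounds with values here, compound 3 `COc1ccc(F)c(-c2ccc(-n3cc(-c4cccc(C(=O)O)c4)nn3)cc2)c1` gives 1170 ug/mL in a physicochemical assay for solubility, measured as thermodynamic solubility (a higher number here means a more soluble compound, a lower number a less soluble compound), the highest of the three numbers so far. Compound 2 `O=C(O)c1cccc(-c2cn(-c3ccc(-c4ccc5c(c4)OCCO5)cc3)nn2)c1` gives 668 ug/mL, and the two lie within the scatter of each other. Compound 1 `COc1cc(OC)cc(-c2ccc(-n3cc(-c4cccc(C(=O)O)c4)nn3)cc2)c1` gives 18.7 ug/mL; the steps of a 36-fold higher number from compound 1 to compound 2 (1.55 log units; beyond the scatter) and a 63-fold higher number from compound 1 to compound 3 (1.80 log units; beyond the scatter) are both large. Compound 4 `COc1cccc(-c2ccc(-n3cc(-c4cccc(C(=O)O)c4)nn3)cc2)c1OC` differs from compound 3 in one place: 2,3-dimethoxyphenyl in place of 2-fluoro-5-methoxyphenyl on an aromatic carbon. Within the data shown here, only the step of a 63-fold higher number from compound 1 to compound 3 (1.80 log units; beyond the scatter), read backwards, bears on this, since compound 1 also carries a dimethoxyphenyl, though with a different arrangement of the two methoxy groups, so the size is uncertain. For compound 4 a downward step a 9.8-fold lower number from compound 3 to compound 4 (0.99 log units; beyond the scatter) is therefore expected. Compound 4 is estimated at 120 ug/mL, ranging from 15 ug/mL to 900 ug/mL.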

Compound 4, solubility: 1530 ug/mL
Estimate against measurement, compound 4: 13-fold (1.11 log units) below; measured number above the stated range.
By their numbers in this assay, from the lowest: compound 1; then compounds 2, 3 and 4 (each within the scatter of the next, the first and the last beyond it).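

Having two methoxy groups on this aromatic carbon's phenyl ring does not by itself go with a low number in this assay: moving them to a different arrangement on that ring gives an 82-fold higher number from compound 1 to compound 4 (1.91 log units; beyond the scatter). Beside the other outer rings, the picture is a 1.3-fold higher number from compound 3 to compound 4 (0.12 log units; within the scatter) and a 2.3-fold higher number from compound 2 to compound 4 (0.36 log units; beyond the scatter), leaving compound 1 as the one far from the rest. Nothing measured here gives a reason for that gap. Still open, from the compounds shown here alone, is whether the low number follows the arrangement of the two methoxy groups in compound 1 generally, for example with an amine or fluorine in place of each methoxy group.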